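A few compounds are considered here, and "the series" means these few. Any claim that something is new, unique, unknown or untested is made for them only; others in the source may bear on it.

Compound 1 `COc1cc(CC(O)(COCc2ccccc2)COCc2ccccc2)nc(OC)n1` and compound 2 `COc1nc(CC(O)(COCc2ccccc2)COCc2ccccc2)c(C)c(OC)n1` share one core, and compound 3 `COCn1c(CC(COCc2ccccc2)COCc2ccccc2)cc(=O)[nH]c1=O` carries a second core; the difference between the two cores is not broken down here. All were tested in a functional assay on HeLa cells (Homo sapiens) for antiproliferative activity, read by MTT assay, with a stated time of 72 h; on this read-out lower numbers stand for stronger inhibition and higher numbers for weaker inhibition. In this assay compound 1 reaches only the limit of the assay, > 100000 nM, and gives no number. Compound 2 gives 3700 nM in this assay. The change between them is methyl in place of hydrogen on an aromatic carbon, and it brings an at least 27-fold lower number from compound 1 to compound 2 (1.43 log units; beyond the scatter). In this assay compound 3 also reaches only a limit, > 100000 nM, so it too gives no number; the picture is shaped by the limit of > 100000 nM in this assay, at which 2 of the 3 values shown sit.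

Compound 4 `COCn1c(CC(COCc2ccccc2)COCc2ccccc2)c(C)c(=O)[nH]c1=O` is not yet measured. It differs from compound 3 by methyl in place of hydrogen on an aromatic carbon. This is the same kind of change as that from compound 1 to compound 2, not the same: in compound 4 the methyl sits ortho to a group of 1 heavy atom, meta to a methoxymethyl group and para to a group of 1 heavy atom, whereas in compound 2 it sits ortho to a methoxy group and para to a methoxy group.

Because compound 3 stands at > 100000 nM, the starting point is only a limit, and the step cannot be expected in the same way as the measured one. Still, compound 4 is expected to move by about an at least 6.6-fold lower number from compound 3 to compound 4 (0.82 log units; beyond the scatter) from compound 3, resting on the size of an at least 27-fold lower number from compound 1 to compound 2 (1.43 log units; beyond the scatter) on the other core. Compound 4 is therefore estimated at 15000 nM in this assay. Its likely range for compound 4 is expected to run from 3000 nM to 100000 nM.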

Compound 4, half-maximal inhibitory concentration: 29700 nM
Compound 4: the middle estimate sits 2.0-fold (0.30 log units) below what was measured; the range from low to high includes it.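

In this assay, methyl in place of hydrogen on an aromatic carbon again goes with a lower number on the second core, an at least 3.3-fold lower number from compound 3 to compound 4 (0.52 log units; beyond the scatter), so the direction seen on the core of compound 1 and compound 2 carries over in the only two pairs shown. This is agreement in direction across two cores, not a measured agreement in size, and the two steps cannot be ranked against each other: the same change on two cores in this assay, an at least 27-fold lower number (1.43 log units; beyond the scatter) from compound 1 to compound 2 and an at least 3.3-fold lower number (0.52 log units; beyond the scatter) from compound 3 to compound 4; the limit leaves it open whether they differ. From the compounds shown here alone, neither step has a measured number at its start, so the true size of the change on either core stays unknown, and two pairs do not establish a rule for the series: the limit of > 100000 nM in this assay, at which 2 of the 4 values shown sit.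

The compounds shown leave open whether the same gain would appear on a third core, and whether it belongs to methyl alone or would also come with an ethyl group, a longer chain or a chlorine atom on that aromatic carbon. They also leave open how an amine or a carboxylic acid in place of the methoxymethyl group would act on the second core, with or without the methyl.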